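Swapping a ring for a chain on a urea inhibitor

This account rests on a few compounds, and the source may have more. Where it says the series, first, only, none or still open, it means among the compounds named here.

Of the compounds shown here, three of a shared core have been tested in an assay on isolated protein for inhibition of ATP-dependent RNA helicase DDX3X (Homo sapiens), read by FRET, with stated times of 30 s and 40 min; on this read-out higher numbers stand for weaker inhibition and lower numbers for stronger inhibition. Compound 1 `COCCc1cn(-c2ccc(NC(=O)Nc3ccccc3C)cc2)nn1` gives 1000 nM in this assay, and compound 3 `CCOC(=O)CCc1cn(-c2ccc(NC(=O)Nc3ccccc3C(F)(F)F)cc2)nn1` gives 2020 nM. Compound 2 `CCCCc1cn(-c2ccc(NC(=O)Nc3cc(OC4CCCC4)ccc3C)cc2)nn1` stands lowest of the three at 140 nM; its gap to compound 1 and its gap to compound 3 both lie beyond the usual scatter, so compound 2 is the strongest inhibitor among the measured set.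

Compound 4 `CCCCc1cn(-c2ccc(NC(=O)Nc3cc(CCC(C)=O)ccc3C)cc2)nn1` has not yet been measured. It differs from compound 2 in one place: 2-acetylethyl in place of cyclopentyloxy on an aromatic carbon. The group that leaves contains a five-membered non-aromatic ring, while the group that enters is an open chain carrying one carbonyl; both hold one hydrogen-bond acceptor and no donor. Among the measured compounds shown here, no pair of measured compounds shows the effect of such a change in isolation, since compound 1 and compound 3 each differ from compound 2 in more than one place.

A modest weakening of inhibition is therefore expected for compound 4, with a step of a 2.3-fold higher number from compound 2 to compound 4 (0.36 log units; beyond the scatter) in this assay. The half-maximal inhibitory concentration of compound 4 in this assay is estimated at 320 nM, most likely between 110 nM and 950 nM.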

Compound 4, half-maximal inhibitory concentration: 2490 nM
Compound 4: middle estimate off by 7.8-fold (0.89 log units), on the low side; the measured number lies above the stated range.
By their numbers in this assay, from the lowest: compound 2; then compound 1; then compounds 3 and 4 (each within the scatter of the next).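

In this assay, replacing cyclopentyloxy with 2-acetylethyl gives an 18-fold higher number from compound 2 to compound 4 (1.25 log units; beyond the scatter), so this position, on the aromatic carbon para to a methyl group, strongly affects inhibition in this series. The large step shows that the choice of group here matters far more than the similar counts suggest: the two groups hold the same numbers of hydrogen-bond donors and acceptors and differ by only one heavy atom, yet one contains a five-membered non-aromatic ring and the other is an open chain carrying a carbonyl. Nothing available explains why this change has such a large effect.

Among the compounds shown here, the single step changes several features at once, leaving open whether the loss of inhibition follows the removal of the ring, the move away from an oxygen attached directly to the aromatic carbon, or the arrival of the carbonyl. A butoxy group, which has the oxygen but no ring, and a pentyl chain, which has neither the oxygen nor the carbonyl, would help separate these features at this same position.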